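The compounds below may be only part of what the source reports. "The series", "measured", "known", "first", "only" and "open" are said of these compounds alone.

Working notes on the series

Three compounds of the set have numbers in a functional assay on CAKI-1 cells (Homo sapiens) for cytotoxicity, read by sulforhodamine B assay, with a stated time of 48 h; on this read-out lower numbers stand for stronger inhibition of growth and higher numbers for weaker inhibition of growth. Compound 3 `ClCc1ccc(Cn2cnc3c(Cl)nc(Cl)nc32)cc1` gives 21400 nM. Compound 1 `Nc1nc(Cl)c2ncn(Cc3ccc(CCl)cc3)c2n1` gives 9770 nM. Going by the values given here, the one change between them, (amino in place of chloro on an aromatic carbon), made a 2.2-fold lower number from compound 3 to compound 1 (0.34 log units; beyond the scatter). Compound 2 `ClCc1cccc(Cn2cnc3c(Cl)nc(Cl)nc32)c1` gives 5880 nM; compound 2 and compound 3 are built from the same atoms joined differently, and the difference between the two cores is not broken down here. The numbers of compound 2 and compound 1 lie within the scatter of each other, so no order between them is read.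

Compound 4 `Nc1nc(Cl)c2ncn(Cc3cccc(CCl)c3)c2n1` has not yet been measured in this assay. It differs from compound 2 by amino in place of chloro on an aromatic carbon. The place of this change is described in the same words as for the change from compound 3 to compound 1, so the two changes are taken as the same change on two cores. Among the compounds with values here, the only precedent for it in the set is the single step of a 2.2-fold lower number from compound 3 to compound 1 (0.34 log units; beyond the scatter), and the estimate for compound 4 rests on that step alone, carried over onto the number of compound 2. Within the data shown here, from compound 2 to compound 4 a step of a 2.2-fold lower number from compound 2 to compound 4 (0.34 log units; beyond the scatter) is expected, because a 2.2-fold lower number from compound 3 to compound 1 (0.34 log units; beyond the scatter) is the only measure of this change so far. Compound 4 is thus estimated at 2700 nM in this assay, with the expected range running from 1200 nM to 6500 nM; one precedent is a thin base, so the range is kept wide.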

Compound 4, concentration for total growth inhibition: 1510 nM
For compound 4 the middle estimate is 1.8-fold (0.25 log units) above the measured one; low and high end bracket the measured number.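

In this assay amino in place of chloro on an aromatic carbon gives a 3.9-fold lower number from compound 2 to compound 4 (0.59 log units; beyond the scatter) and this step can be set beside the earlier one on the other core: the same change on two cores in this assay, a 2.2-fold lower number (0.34 log units; beyond the scatter) from compound 3 to compound 1 and a 3.9-fold lower number (0.59 log units; beyond the scatter) from compound 2 to compound 4, 1.8-fold (0.25 log units) apart, within the scatter of two such steps.

The number is lower after the change on both cores shown, and no difference in the size of the step can be read between them, so in this series the earlier step was a fair guide to direction and to size within the scatter. Going by these compounds alone, this rests on only two steps, on two cores built from the same atoms joined differently, so it does not show that the step would carry over to a core of another kind, and it gives no reason for the step. It also does not separate what the entering amino group does from what the leaving chloro group does.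

The compounds shown leave open whether a dimethylamino, methoxy or hydroxyl group in place of chloro on this same carbon would move the number in the same way as amino. They also leave open what the chloromethyl group contributes, as a hydroxymethyl or plain methyl group in its place would have to show.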